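Replacing benzothiazolyl with nitro: an expected cytotoxicity step

A few compounds are considered here, and "the series" means these few. Any claim that something is new, unique, unknown or untested is made for them only; others in the source may bear on it.

Compound 1 `CC1(C)OC(=O)C(=CNc2cccc(-c3nc4ccccc4s3)c2)C(=O)O1`: 115000 nM in an ADME assay on THP-1 cells (Homo sapiens) for cytotoxicity, read by flow cytometry and propidium iodide staining, with a stated time of 72 h; on this read-out lower numbers stand for stronger inhibition and higher numbers for weaker inhibition
Compound 2 `CC1(C)OC(=O)C(=CNc2ccc3[nH]nnc3c2)C(=O)O1`: > 500000 nM, a limit of the assay
Compound 3 `O=c1cc[nH]c2c([N+](=O)[O-])cccc12`: > 500000 nM, a limit of the assay

For the measured compounds named here, compound 1 is the only compound that gives a number in this assay; the other two values are limits, as the limit of > 500000 nM in this assay, at which 2 of the 3 values shown sit, records. Compound 4 `CC1(C)OC(=O)C(=CNc2cccc([N+](=O)[O-])c2)C(=O)O1` has not yet been measured. It differs from compound 1 in one place: nitro in place of 1,3-benzothiazol-2-yl on an aromatic carbon. Going by the values given here, no step between measured compounds is available, so the size of this change cannot be read from the data. Compound 4 is expected to be weaker than compound 1 in this assay, a step of a 3.5-fold higher number from compound 1 to compound 4 (0.54 log units; beyond the scatter) that would lie beyond the scatter. The estimate for compound 4 is 400000 nM, with a range from 120000 nM to 1500000 nM.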

Compound 4, half-maximal inhibitory concentration: > 250000 nM
Compound 4: only a limit was reported; the forecaster's own chance of this, stated with the estimate: 50%; the middle value does not contradict the limit.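

In this assay, for the compounds shown here, nitro in place of 1,3-benzothiazol-2-yl on an aromatic carbon brings an at least 2.1-fold higher number from compound 1 to compound 4 (0.33 log units; beyond the scatter), the first step that can be read at this place. Compound 4 gives only a limit, so this step has a floor but no upper end: the limit of > 250000 nM in this assay, at which 1 of the 4 values shown sits. Among the compounds shown, only compound 1, which carries 1,3-benzothiazol-2-yl, gives a number.

From the compounds shown here alone, what an amine or a carboxylic acid would give on this aromatic carbon remains open. So does whether a plain phenyl ring there would restore a measurable number.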